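The source may hold more compounds than are shown below. What is called first, only, known or untested is meant among the compounds shown, and "the series" means these compounds.

For the measured compounds named here, compound 1 `Cc1cc(C#N)cc(C)c1Oc1nc(Nc2ccc(C#N)cc2)nc2ccccc12` gives 203000 nM in an ADME assay on MT4 cells (Homo sapiens) for cytotoxicity, read by MTT assay, with a stated time of 4 days (a lower number here means that less compound is tolerated, a higher number that more compound is tolerated), the highest of the two numbers so far. Compound 2 `N#Cc1ccc(Nc2nc(Oc3ccccc3Cl)c3ccccc3n2)cc1` gives 38000 nM in this assay, a step of a 5.3-fold lower number from compound 1 to compound 2 (0.73 log units; beyond the scatter). Compound 3 `COc1ccccc1Oc1nc(Nc2ccc(C#N)cc2)nc2ccccc12` differs from compound 1 by 2-methoxyphenyl in place of 4-cyano-2,6-dimethylphenyl on an oxygen on an aromatic ring. Going by the values given here, the one measured step that bears on it is the exchange on an oxygen on an aromatic ring from compound 1 to compound 2, which was modest and downward, so a lower number of similar size is expected here. Compound 3 is therefore expected to give 50000 nM, within 15000 nM to 160000 nM. This implies an expected step of a 4.1-fold lower number from compound 1 to compound 3 (0.61 log units; beyond the scatter).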

Compound 3, half-maximal cytotoxic concentration: 150000 nM
Estimate against measurement, compound 3: 3.0-fold (0.48 log units) below; measured number inside the range.
By their numbers in this assay, from the lowest: compound 2; then compounds 3 and 1 (each within the scatter of the next).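

Working from this assay, 2-methoxyphenyl on an oxygen on an aromatic ring gives a 1.4-fold lower number from compound 1 to compound 3 (0.13 log units; within the scatter), so the departure of 4-cyano-2,6-dimethylphenyl does not by itself go with a lower number. The lower number of compound 2 therefore appears tied to the chloro group, as methoxy in place of chloro on an aromatic carbon gives a 3.9-fold higher number from compound 2 to compound 3 (0.60 log units; beyond the scatter). Going by these compounds, whether an amine or a carboxylic acid on that aromatic carbon would stay with compound 3 or with compound 2 remains open. No measurement at hand accounts for the gap between methoxy and chloro.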